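The source may hold more compounds than are shown below. What is called first, only, known or untested is meant among the compounds shown, and "the series" means these compounds.

Working notes on the series.

Compound 1 `COc1cc(/C(Cl)=C/C=C(\C#N)C(=O)c2c[nH]c3ccccc23)cc(OC)c1OC` is the reference point here. In a functional assay for inhibition, with a stated time of 5 min, tested at 1 mM (on this read-out higher numbers stand for more inhibition at the one concentration tested (going by the name of the read-out) and lower numbers for less inhibition), compound 1 gives 59.1%. Among the measured compounds shown here, the only other measured member is compound 2 `COc1ccc(/C(Cl)=C/C=C(\C#N)C(=O)c2c[nH]c3ccc(Br)cc23)cc1`, which in this assay gives 62.2%; on the two numbers in hand compound 1 sits alongside compound 2, the gap between them falling within the usual scatter of this kind of measurement, so the two read as equivalent. For the measured compounds named here, compound 2 also differs from compound 1 in more than one place, so it yields no single-point step that could be carried over.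

The next member is compound 3 `COc1cc(/C(Cl)=C/C=C(\C#N)C(=O)c2c[nH]c3ccc(Br)cc23)cc(OC)c1OC`. It differs from compound 1 in exactly one way: bromo in place of hydrogen on an aromatic carbon. Going by the values given here, no measured pair shows this change on its own, and the two available numbers give no indication of a shift that would clear the scatter. The expected step in this assay from compound 1 to compound 3 is therefore a number 1.9 percentage points higher from compound 1 to compound 3 (within the scatter), that is, none beyond the scatter. On that basis compound 3 is estimated to give 61% in this assay, with a range of 46% to 76%.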

Compound 3, a percentage reported as inhibition, at one concentration (the size of the read-out at that concentration, not a potency): 50%
Compound 3: middle estimate off by 11 percentage points, on the high side; low and high end bracket the measured number.
By their numbers in this assay, from the lowest: compounds 3, 1 and 2 (each within the scatter of the next, the first and the last beyond it).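

Among the compounds shown here, this is the first single-point step: in this assay, swapping 1H-indol-3-yl for 5-bromo-1H-indol-3-yl on the core of compound 1 gives a number 9.1 percentage points lower from compound 1 to compound 3 (within the scatter). On this one pair, bromo in place of hydrogen on this aromatic carbon, the position that the computed comparison places meta to a fused ring and para to a fused ring, does not separate the two compounds, and the inhibition in this assay reads level at the single concentration tested. No separate measurement is available to explain the size of this step or to relate it to any property of the bromo group.

As far as these compounds go, whether a group of another kind on the same aromatic carbon, such as an amine, a carboxylic acid or a longer chain such as n-butyl, would give a step beyond the scatter remains open. Also open, from the compounds shown here alone, is whether the bromo step would read the same on a core carrying other substituents, since a single pair gives no basis for carrying it over to other compounds.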